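A few compounds are considered here, and "the series" means these few. Any claim that something is new, unique, unknown or untested is made for them only; others in the source may bear on it.

Measured in a physicochemical assay for lipophilicity, at pH 7.4; on this read-out higher numbers stand for higher lipophilicity and lower numbers for lower lipophilicity:
- compound 1 `CC(C)Oc1ccc(-c2nnc(-c3cnn(CC(=O)O)c3)s2)cc1Cl`: 2.82
- compound 2 `CC(C)Oc1ccc(-c2nnc(-c3ccnn3C)s2)cc1Cl`: 7.04

Of these two, compound 2 has the higher number at 7.04. Compound 1 stands lower, and the gap lies well beyond the usual scatter of this assay. Compound 3 `CC(C)Oc1ccc(-c2nnc(-c3cn[nH]c3)s2)cc1Cl` has not yet been measured. It differs from compound 2 in one place, with 1H-pyrazol-4-yl in place of 1-methyl-1H-pyrazol-5-yl on an aromatic carbon. For the measured compounds named here, no two measured compounds differ in only one place, so no measured step sets the size of this one, and the expectation is a judgement with a wide range. A fall beyond the scatter is expected: a number 1.04 log units lower from compound 2 to compound 3 (beyond the scatter). Compound 3 is still expected to stay well above compound 1 at 2.82. For compound 3 the estimated value is 6, with an expected range from 5 to 6.9.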

Compound 3, distribution coefficient: 5
Beside the measured number, compound 3's estimate is 1.00 log units above it; the range from low to high includes it.
By their numbers in this assay, from the lowest: compound 1; then compound 3; then compound 2.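

In this assay, compound 3 splits the wide gap between the two earlier compounds into two single changes, and both are large. Putting 1H-pyrazol-4-yl in place of 1-methyl-1H-pyrazol-5-yl on the aromatic carbon gives a number 2.04 log units lower from compound 2 to compound 3 (beyond the scatter), while putting hydrogen in place of carboxymethyl on the aromatic nitrogen of that ring gives a number 2.18 log units higher from compound 1 to compound 3 (beyond the scatter). No measurement here explains either step.

The first step removes the methyl group, moves the ring's point of attachment and adds a hydrogen-bond donor all at once, so the share of each remains unresolved; 1-methyl-1H-pyrazol-4-yl would separate the attachment from the methyl group. The second step leaves open how a neutral group on that nitrogen, such as a methyl ester or a longer alkyl chain, would compare with hydrogen and carboxymethyl.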